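Akata-cell cytotoxicity of aminopurine cyclopropylidene derivatives

This account rests on a few compounds, and the source may have more. Where it says the series, first, only, none or still open, it means among the compounds named here.

Measured compounds:
compound 1, `CCCNc1nc(N)nc2c1ncn2/C=C1/CC1(CO)CO`; in an ADME assay on Akata cells (Homo sapiens) for cytotoxicity, with a stated time of 7 days (on this read-out lower numbers stand for higher toxicity in this test and higher numbers for lower toxicity in this test), compound 1 gives > 24000 nM, a limit of the test.
compound 2, `CC(C)CNc1nc(N)nc2c1ncn2/C=C1/CC1(CO)CO`; in this assay compound 2 gives > 24000 nM, again a limit.
compound 3, `CCCCNc1nc(N)nc2c1ncn2/C=C1/CC1(CO)CO`; in this assay compound 3 gives > 24000 nM, also a limit.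

All three values sit at the same limit, (the limit of > 24000 nM in this assay, at which 3 of the 3 values shown sit), so compound 3 cannot be placed relative to compound 1 or compound 2; the steps a step that the two limits leave unreadable from compound 1 to compound 3 and a step that the two limits leave unreadable from compound 2 to compound 3 are both unreadable, as is a step that the two limits leave unreadable from compound 1 to compound 2.

Compound 4, `CCCCCCCCSc1nc(N)nc2c1ncn2/C=C1/CC1(CO)CO`, has not yet been measured. It differs from compound 3 by octylsulfanyl in place of butylamino on an aromatic carbon. Going by the values given here, the step from compound 2 to compound 3 alters the same position, but its size is not readable, and no measured step exchanges the nitrogen of the butylamino group for a sulfur, so the data give no direction for this change. The working expectation is that compound 4 also sits at the limit of this assay, with the expected step that the limit leaves unreadable from compound 3 to compound 4 carrying little weight. The estimate for compound 4 is 28000 nM, within a range from 9000 nM to 90000 nM.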

Compound 4, half-maximal cytotoxic concentration: > 20000 nM
Compound 4 ended at the assay's limit (the forecaster's own chance of this, stated with the estimate: 60%); the middle value lies beyond the limit too.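

Compound 4 gives > 20000 nM in this assay, which is a limit. The steps to compound 4 from compound 1, compound 2 and compound 3 therefore cannot be read. The compounds shown leave open whether any of these groups on the shared core reaches a measurable half-maximal cytotoxic concentration in this assay.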